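The source may report more compounds than this note shows. Statements on the series, on what has been measured and on what is new or still open speak of the compounds shown alone.

Of the compounds shown here, two have so far been measured in an ADME assay on the whole organism (plasma, Mus musculus, strain CD1), read by LC-MS, with a stated time of 24 h; a higher number here means a larger unbound share of the compound, a lower number a smaller unbound share. Compound 1, `O=C(O)Cn1nc(Cc2nc3cc(Cl)c(OCC(F)F)cc3[nH]2)c2ccccc2c1=O`, gives 0.038 in this assay. Compound 2, `CCC(C(=O)O)c1nn(Cc2cn3cc(OCC4CC4)c(Cl)cc3n2)c2ccccc2c1=O`, gives 0.013 in this assay. On these two numbers compound 1 stands highest, and its nearest neighbour, compound 2, lies a clear distance below it, farther apart than repeated runs of this kind usually scatter. Among the measured compounds shown here, no pair differing in a single place links the two measured compounds, so their values can only be set side by side without reading a step between them.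

Compound 3, `O=C(O)Cn1nc(Cc2nc3cc(Cl)c(OCC4CC4)cc3[nH]2)c2ccccc2c1=O`, has not yet been measured in this assay. It keeps the core of compound 1 and differs from it in one place: cyclopropyl in place of difluoromethyl on a saturated chain carbon bound to an oxygen on an aromatic ring. Compound 2 also carries a cyclopropylmethoxy group and shows the lower of the two known values, but its core differs in more than that one place, so it offers only a hint. The step expected here, a 1.5-fold lower number from compound 1 to compound 3 (0.18 log units; within the scatter), is a small decrease, at most narrowly beyond the scatter. For compound 3 the estimated unbound fraction is 0.025, within a range from 0.012 to 0.05.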

Compound 3, unbound fraction: 0.012
Beside the measured number, compound 3's estimate is 2.1-fold (0.32 log units) above it; measured number inside the range.
By their numbers in this assay, from the lowest: compounds 3 and 2 (each within the scatter of the next); then compound 1.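

Among the compounds shown here, with compound 3, a single change can be read for the first time in this assay: on the shared core, cyclopropyl in place of difluoromethyl gives a 3.2-fold lower number from compound 1 to compound 3 (0.50 log units; beyond the scatter). This shows that the position matters for the unbound share, even though the two groups have the same count of heavy atoms, and neither has hydrogen-bond donors or acceptors or a net charge. Nothing measured here explains why the swap has this effect.

This one step changes two things at once, removing the two fluorine atoms and adding a three-membered ring, so it cannot show which of them matters, and a plain ethyl or propyl chain on the same oxygen would help to separate the two. Also open, as far as these compounds go, are whether a longer chain or a chain ending in an amine at this place would shift the unbound share further, and whether the same swap would give a similar step on a different core.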